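The source may hold more compounds than are shown below. What is called first, only, known or untested is meant among the compounds shown, and "the series" means these compounds.

Measured in a functional assay for inhibition, with Cavia porcellus as the target; on this read-out higher numbers stand for weaker inhibition and lower numbers for stronger inhibition:

compound 1 `CC1=NC(C)=C([N+](=O)[O-])C(c2ccccn2)/C1=C(\O)OC1CCCC1`: 450 nM
compound 2 `CC1=NC(C)=C([N+](=O)[O-])C(c2ccccn2)/C1=C(\O)OC(C)(C)C`: 1930 nM

For the measured compounds named here, compound 1 holds the lower of the two numbers and so shows the stronger inhibition, with compound 2 as its only neighbour. Compound 3 `COCCO/C(O)=C1\C(C)=NC(C)=C([N+](=O)[O-])C1c1ccccn1` has not yet been measured. It keeps the core of compound 1 and differs in one group: 2-methoxyethyl in place of cyclopentyl on an oxygen on an unsaturated carbon. In words, this is 2-methoxyethyl in place of cyclopentyl on an oxygen on an unsaturated carbon. Going by the values given here, only one measured step touches that place: a 4.3-fold higher number from compound 1 to compound 2 (0.63 log units; beyond the scatter), a modest change with tert-butyl in place of cyclopentyl. Among the compounds with values here, that step brings in a different group, so it offers a scale rather than a direct reading for 2-methoxyethyl, and no measured compound carries an open chain with an oxygen there. Resting on compound 2 at 1930 nM, a step of similar or smaller size towards a higher number is expected in this assay. The expected change is a 2.2-fold higher number from compound 1 to compound 3 (0.35 log units; beyond the scatter). For compound 3 the estimated value is 1000 nM, with a range of 300 nM to 3200 nM.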

Compound 3, half-maximal inhibitory concentration: 94700 nM
Estimate against measurement, compound 3: 95-fold (1.98 log units) below; the measured number lies above the stated range.
By their numbers in this assay, from the lowest: compound 1; then compound 2; then compound 3.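

Within this assay, the group on an oxygen on an unsaturated carbon turns out to matter far more than the first pair suggested, since a 4.3-fold higher number from compound 1 to compound 2 (0.63 log units; beyond the scatter) is only a modest step. Replacing the two groups with 2-methoxyethyl gives much larger steps, a 210-fold higher number from compound 1 to compound 3 (2.32 log units; beyond the scatter) and a 49-fold higher number from compound 2 to compound 3 (1.69 log units; beyond the scatter), leaving compound 3 with the weakest inhibition of the three. Among these compounds, cyclopentyl and tert-butyl therefore lie much closer to each other than either lies to the open chain with an oxygen, and nothing available accounts for the size of this loss.

What the compounds leave open is whether the loss goes with the oxygen in the chain or with the open, ring-free shape, as 2-methoxyethyl differs from cyclopentyl in both respects. A plain butyl chain and a tetrahydrofuranyl ring would pull those two apart, and a longer ether chain or a chain ending in an amine would show whether the steep loss extends to other open chains at this place.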